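The source may report more compounds than this note shows. Statements on the series, on what has been measured and on what is new or still open speak of the compounds shown alone.

In a functional assay on the whole organism (strain Kunming) with Mus musculus as the target, with a stated time of 0.5 h, at a dose of 300 mg/kg by the intraperitoneal route (on this read-out higher numbers stand for a weaker effect at the one dose given and lower numbers for a stronger effect), compound 1 `COc1cc(OC)c(OC)cc1/C=C/COC(=O)/C=C/c1cc(OC)c(OC)c(OC)c1` gives 100%. Compound 2 `COc1cc(OC)c(OC)cc1/C=C/COC(=O)/C=C/c1cccc(Br)c1` gives in this assay a reading of 100%, so compound 2 stands level with compound 1 at the digits shown, the two values lying within the scatter of each other; nothing separates them on this read-out. Compound 3 `COc1cc(OC)c(OC)cc1/C=C/COC(=O)/C=C/c1ccc(Cl)cc1` has not yet been measured in this assay. It differs from compound 2 in one place: 4-chlorophenyl in place of 3-bromophenyl on a double-bonded chain carbon bound to a double-bonded chain carbon. Among the measured compounds shown here, no step between measured compounds is available from which a direction for this change could be drawn, and both measured values sit at the same reading. The step of no change at the digits printed from compound 2 to compound 3 (within the scatter) is expected to stay within the scatter. This expectation rests only on compound 2, which gives 100%, and on compound 1, which gives 100%. Compound 3 is estimated at 100%, between 85% and 100%.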

Compound 3, a percentage reported as activity, at one dose (the size of the read-out at that dose, not a potency): 100%
Compound 3: middle estimate and measured number agree at the digits printed; the measured number falls inside the stated range.
By their numbers in this assay, from the lowest: compounds 1, 2 and 3 (each within the scatter of the next).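

Among the compounds shown here, with the step of no change at the digits printed from compound 2 to compound 3 (within the scatter) in this assay, there is now a direct comparison at this position, which the earlier compounds did not offer: 4-chlorophenyl in place of 3-bromophenyl on a double-bonded chain carbon bound to a double-bonded chain carbon leaves the reading within the scatter. Chlorine replaces bromine and the halogen's place on the phenyl ring differs as well, so this single step cannot separate the two alterations. No supporting measurement bears on this result.

The compounds shown leave open whether a different kind of group at this position, such as an amine or a carboxylic acid on the phenyl ring, would give a reading apart from that of compound 2. They also leave open whether a longer chain in place of the double-bonded chain would do so.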